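The compounds below may be only part of what the source reports. "The series", "measured", "known", "first", "only" and "open" are said of these compounds alone.

Among the measured compounds shown here, compound 3 `CC(C)(C)c1ccc(C(=O)N2CCC3(CC2)C(=O)N(CC(=O)NCCCCO)CN3c2ccccc2)cc1` gives 19200 nM in an assay on HEK293 cells for displacement of a labelled ligand from NPC1-like intracellular cholesterol transporter 1 (Homo sapiens) (a lower number here means a stronger inhibitor, a higher number a weaker inhibitor), the highest of the three numbers measured so far, though both neighbours lie within the usual scatter. Compound 1 `O=C(CN1CN(c2ccccc2)C2(CCN(C(=O)c3ccc(C4CCCCC4)cc3)CC2)C1=O)NCCCCO` gives 10300 nM in this assay, and compound 2 `CC(C)(C)OC(=O)NCCCCCNC(=O)CN1CN(c2ccccc2)C2(CCN(C(=O)c3ccc(C(C)(C)C)cc3)CC2)C1=O` gives 13700 nM. Both steps toward compound 3 were small: a 1.9-fold higher number from compound 1 to compound 3 (0.27 log units; within the scatter) and a 1.4-fold higher number from compound 2 to compound 3 (0.15 log units; within the scatter).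

Compound 4 `CC1CCCN(C(=O)CN2CN(c3ccccc3)C3(CCN(C(=O)c4ccc(C(C)(C)C)cc4)CC3)C2=O)C1` differs from compound 3 in one place: 3-methylpiperidin-1-yl in place of (4-hydroxybutyl)amino on a carbonyl carbon. For the measured compounds named here, no measured step replaces the (4-hydroxybutyl)amino group as a whole; the nearest, a 1.4-fold higher number from compound 2 to compound 3 (0.15 log units; within the scatter), alters only the chain end and stays within the scatter. With nothing pointing either way, compound 4 is expected to give 20000 nM in this assay, between 6000 nM and 60000 nM. The expected step is a 1.0-fold higher number from compound 3 to compound 4 (0.02 log units; within the scatter), not beyond the scatter.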

Compound 4, half-maximal inhibitory concentration: 12000 nM
Beside the measured number, compound 4's estimate is 1.7-fold (0.22 log units) above it; the range from low to high includes it.
By their numbers in this assay, from the lowest: compounds 1, 4, 2 and 3 (each within the scatter of the next).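

Replacing the whole (4-hydroxybutyl)amino group on the carbonyl carbon with 3-methylpiperidin-1-yl gives a 1.6-fold lower number from compound 3 to compound 4 (0.20 log units; within the scatter) in this assay for this pair. A group with no hydrogen-bond donors and a six-membered non-aromatic ring can therefore take the place of an open chain with donors here, with no change beyond the scatter. No supporting measurement bears on why this is so. As far as these compounds go, whether an amine, a carboxylic acid or a longer chain on this carbonyl carbon would move the number beyond the scatter stays open. So does the part played by the methyl group on the piperidine ring.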